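Swapping the enone side chain for a hydroxybutyl chain

This account rests on a few compounds, and the source may have more. Where it says the series, first, only, none or still open, it means among the compounds named here.

Measured so far:
Compound 1, `COc1ccc2cc(CCC(C)(C)O)ccc2c1`: 3%
Compound 2, `CC(=O)/C=C/c1ccc2cc(C)ccc2c1`: 29%

Both compounds were tested in a functional assay on the whole organism (strain Wistar) for inhibition, with Rattus norvegicus as the target, with a stated time of 5 days, at a dose of 50 mg/kg by the oral route; on this read-out higher numbers stand for more inhibition at the one dose given (going by the name of the read-out) and lower numbers for less inhibition. Of the two numbers, compound 2 stands highest, and compound 1 sits well below it, a gap beyond the usual scatter. The unmeasured compound 3, `Cc1ccc2cc(CCC(C)O)ccc2c1`, is derived from compound 2 by a single change: 3-hydroxybutyl in place of 2-acetylethenyl on an aromatic carbon. The carbonyl and the double bond of the side chain are thus gone, replaced by a saturated chain ending in a hydroxyl. Within the data shown here, no measured pair shows this exact step, so its size can only be guessed. Compound 1, whose side chain also ends in a hydroxyl rather than a carbonyl, gives 3% in this assay, which points downward. The expected step of a number 21 percentage points lower from compound 2 to compound 3 (beyond the scatter) is therefore a drop beyond the scatter. For compound 3 the estimate in this assay is 8%, within 0% to 25%.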

Compound 3, a percentage reported as inhibition, in the whole organism at one dose (the size of the read-out at that dose, not a potency): 35%
For compound 3 the middle estimate is 27 percentage points below the measured one, and the stated range ends below it.
By their numbers in this assay, from the lowest: compound 1; then compounds 2 and 3 (each within the scatter of the next).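

In this assay the swap of 2-acetylethenyl for 3-hydroxybutyl on an aromatic carbon of the shared core gives a number 6 percentage points higher from compound 2 to compound 3 (within the scatter) and so leaves the read-out within its usual spread. At this position, then, the carbonyl and the side-chain double bond are not required for inhibition at this dose, since a saturated chain ending in a hydroxyl serves as well. Nothing available explains why these two different side chains read alike.

The compounds shown do not separate the roles of the carbonyl, the double bond and the hydroxyl, which a saturated 3-oxobutyl chain or a plain butyl chain on the same core could begin to do. On these data alone, how a chain ending in an amine or a carboxylic acid, or a longer chain, would behave here also remains open.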